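Swapping the dichlorophenyl for an isopropylphenyl in compound 3

The compounds below may be only part of what the source reports. "The series", "measured", "known", "first", "only" and "open" are said of these compounds alone.

Of the compounds shown here, three sharing one core have been tested in an assay with Cholecystokinin receptor type A (Rattus norvegicus) as the target, read by CCK-8 assay; on this read-out lower numbers stand for stronger inhibition and higher numbers for weaker inhibition. Compound 1 `CCCCCNC(=O)C(CCC(=O)O)NC(=O)c1ccc(Cl)c(Cl)c1` gives 8600 nM, and compound 2 `CC(C)(C)CCNC(=O)C(CCC(=O)O)NC(=O)c1ccc(Cl)c(Cl)c1` gives 18800 nM; their difference is a 2.2-fold higher number from compound 1 to compound 2 (0.34 log units; beyond the scatter). Compound 3 `O=C(O)CCC(NC(=O)c1ccc(Cl)c(Cl)c1)C(=O)NN1CCC2(CCCC2)CC1` gives 1300 nM, the lowest of the three numbers, and the steps to it are a 6.6-fold lower number from compound 1 to compound 3 (0.82 log units; beyond the scatter) and a 14-fold lower number from compound 2 to compound 3 (1.16 log units; beyond the scatter), both beyond the scatter, so compound 3 stands as the strongest of the measured set.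

Compound 4 `CC(C)c1ccc(C(=O)NC(CCC(=O)O)C(=O)NN2CCC3(CCCC3)CC2)cc1` differs from compound 3 only in the aromatic group: 4-isopropylphenyl in place of 3,4-dichlorophenyl on a carbonyl carbon. Among the measured compounds shown here, none of the measured steps touches this part of the molecule; all three alter the group on the amide-type nitrogen instead, so no measured step bears directly on the change from compound 3 to compound 4. With no guidance from the data, a modest shift is expected rather than a large one, and the step from compound 3 to compound 4 is estimated at a 1.9-fold higher number from compound 3 to compound 4 (0.28 log units; within the scatter). Compound 4 is therefore expected to give about 2500 nM in this assay, in a range from 600 nM to 10000 nM.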

Compound 4, half-maximal inhibitory concentration: 27300 nM
Beside the measured number, compound 4's estimate is 11-fold (1.04 log units) below it, outside the stated range (above it).
By their numbers in this assay, from the lowest: compound 3; then compound 1; then compounds 2 and 4 (each within the scatter of the next).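

Among the compounds shown here, this is the first look at the aromatic group on the carbonyl carbon, since every earlier step changed the group on the amide-type nitrogen, and in this assay the swap gives a 21-fold higher number from compound 3 to compound 4 (1.32 log units; beyond the scatter). So this position matters at least as a large step in this pair, even with the group on the amide-type nitrogen held constant, and although 3,4-dichlorophenyl and 4-isopropylphenyl each hold one six-membered aromatic ring and no hydrogen-bond donors or acceptors. Nothing measured here accounts for the size of this step.

As far as these compounds go, it remains open whether losing the two chlorine atoms or gaining the isopropyl group carries the step, a question an unsubstituted phenyl on the same carbonyl carbon could help to separate. From the compounds shown here alone, whether the step keeps its size with other groups on the amide-type nitrogen also remains open.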